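A few compounds are considered here, and "the series" means these few. Any claim that something is new, unique, unknown or untested is made for them only; others in the source may bear on it.

Measured so far, in a functional assay on cells for antagonist activity at Free fatty acid receptor 1 (Homo sapiens), read by TR-FRET and inositol phosphate accumulation, with a stated time of 2 h; a higher number here means a weaker inhibitor, a lower number a stronger inhibitor:
compound 1 `Cc1cc(COc2cccc(Cl)c2)nc(-c2ccccn2)n1` gives 398 nM
compound 2 `Cc1cc(COc2ccc(C#N)cc2)nc(-c2ccccn2)n1` gives 31600 nM
compound 3 `Fc1ccc(OCc2cc(N3CC4(CCO4)C3)nc(-c3ccccn3)n2)c(F)c1F` gives 501 nM

Compound 3 holds the second highest of the three numbers. Its nearest neighbour is compound 1, whose value lies within the scatter of it; compound 2 stands far higher, beyond the scatter, and is the only clearly weaker inhibitor of the set. Compound 4 `Fc1ccc(OCc2cc(OCC3(F)COC3)nc(-c3ccccn3)n2)c(F)c1F` keeps the whole of compound 3 except for one exchange on the shared core: a group of 7 heavy atoms (4 carbon, 2 oxygen, 1 fluorine; one four-membered non-aromatic ring with 1 hetero atom) in place of a group of 7 heavy atoms (5 carbon, 1 nitrogen, 1 oxygen; 2 four-membered non-aromatic rings with 1 hetero atom each), on an aromatic carbon. Among the measured compounds shown here, no measured pair shows this exchange, so nothing fixes its size or direction. The expectation is a modest shift in this assay, perhaps a somewhat higher number, and the step of a 1.6-fold higher number from compound 3 to compound 4 (0.20 log units; within the scatter) is estimated as small, possibly within the scatter. Compound 4 is expected at 800 nM, within a range of 250 nM to 2500 nM.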

Compound 4, half-maximal inhibitory concentration in the Free fatty acid receptor 1 assay: 63.1 nM
For compound 4 the middle estimate is 13-fold (1.10 log units) above the measured one, and the stated range ends above it.
By their numbers in the Free fatty acid receptor 1 assay, from the lowest: compound 4; then compounds 1 and 3 (each within the scatter of the next); then compound 2.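

On the aromatic carbon next to the ring nitrogen, (3-fluorooxetan-3-yl)methoxy replaces a group of equal heavy-atom count and gives, in the Free fatty acid receptor 1 assay, a 7.9-fold lower number from compound 3 to compound 4 (0.90 log units; beyond the scatter), so this position responds clearly to what it carries. In a physicochemical assay for lipophilicity, at pH 7.4 (a lower number here means a more polar compound, a higher number a more lipophilic compound), compound 3 gives 3.3 and compound 4 gives 4. The exchange also raises lipophilicity in the physicochemical assay: the measured distribution coefficient of compound 3, 3.3, and of compound 4, 4, a number 0.70 log units higher (beyond the scatter)

One pair cannot separate the gain in inhibition from that rise, nor show which part of the new group carries it. As far as these compounds go, whether a plain ethoxy, a longer alkoxy chain or a primary amine at this position would keep the inhibition remains open.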